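The compounds below may be only part of what the source reports. "The series", "measured", "known", "first", "only" and "open" are said of these compounds alone.

Notes on the series. Compound 1 `CCCOc1cccnc1-c1ccc(C(=O)Nc2ccc(C(C)(C)C)cc2)cc1` gives 20 nM in a functional assay for antagonist activity at transient receptor potential cation channel subfamily V member 1 (Rattus norvegicus); a lower number here means a stronger inhibitor, a higher number a weaker inhibitor. Compound 2 `CC(C)(C)c1ccc(NC(=O)c2ccc(-c3ncccc3C(=N)N)cc2)cc1` is the same core with a different group on the pyridine ring. In this assay compound 2 gives > 4000 nM, and this is a limit of the assay rather than a number. The step from compound 1 to compound 2 is an at least 200-fold higher number from compound 1 to compound 2 (2.30 log units; beyond the scatter); compound 2 therefore stands at the limit of > 4000 nM in this assay, at which 1 of the 2 values shown sits, the weaker end of what has been seen so far.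

Compound 3 `CC(C)(C)c1ccc(NC(=O)c2ccc(-c3ncccc3-c3nnco3)cc2)cc1` is still to be measured. Relative to compound 2 the change is a group of 5 heavy atoms (2 carbon, 2 nitrogen, 1 oxygen; one five-membered aromatic ring with 3 hetero atoms) in place of a group of 3 heavy atoms (1 carbon, 2 nitrogen; no ring), on an aromatic carbon. Among the measured compounds shown here, only the step from compound 1 to compound 2 bears on this position, and it was an at least 200-fold higher number from compound 1 to compound 2 (2.30 log units; beyond the scatter), so this position tolerates at least one exchange poorly. Whether the ring in compound 3 fares better than the group it replaces is open. Compound 3 is expected to give 400 nM in this assay, within 60 nM to 4000 nM, an estimated step of an at least 10-fold lower number from compound 2 to compound 3 (1.00 log units; beyond the scatter) from the limit of compound 2.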

Compound 3, half-maximal inhibitory concentration: 59 nM
The estimate for compound 3 lay 6.8-fold (0.83 log units) above the measured number; the measured number lies below the stated range.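

Compound 2 is held only by a limit of the assay in this assay: the limit of > 4000 nM in this assay, at which 1 of the 3 values shown sits.

Even so, the position is not closed to exchange: with 1,3,4-oxadiazol-2-yl in place of the group of compound 2, the result is an at least 67-fold lower number from compound 2 to compound 3 (1.83 log units; beyond the scatter), so a five-membered aromatic ring with 3 hetero atoms and 0 hydrogen-bond donors is accepted here. The ring does not fully match propoxy, with a 3.0-fold higher number from compound 1 to compound 3 (0.47 log units; beyond the scatter), so compound 1 keeps the lower number.

The compounds shown do not separate whether the gain follows the ring itself, its hetero atoms, or the absence of the hydrogen-bond donors present in compound 2. On these data alone, how an amine, a carboxylic acid or a longer alkoxy chain such as butoxy would fare at this position remains open.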